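Replacing furan-2-yl with 3-methoxyphenyl: working notes

The source may hold more compounds than are shown below. What is called first, only, known or untested is meant among the compounds shown, and "the series" means these compounds.

In a functional assay on HEY cells (Homo sapiens) for cytotoxicity, read by MTT assay, with a stated time of 72 h (a higher number here means a weaker inhibitor, a lower number a stronger inhibitor), compound 1 (`N[C@H]1CC[C@H](Nc2c(C(=O)NCc3ccco3)nc(Br)c3cccnc23)CC1`) gives > 10000 nM, which is a limit of the assay and not a number. Compound 2 (`N[C@H]1CC[C@H](Nc2c(C(=O)NCc3ccc(Oc4ccccc4)cc3)nc(Br)c3cccnc23)CC1`) gives a measured number, 9000 nM. Next in line is compound 3 (`COc1cccc(CNC(=O)c2nc(Br)c3cccnc3c2N[C@H]2CC[C@H](N)CC2)c1`), not yet measured. It departs from compound 1 by 3-methoxyphenyl in place of furan-2-yl on a saturated chain carbon bound to an amide-type nitrogen. Within the data shown here, the only number so far, from compound 2 at 9000 nM, gives no sign of a large shift in this assay. The expected size of an at least 1.1-fold lower number from compound 1 to compound 3 (0.04 log units; that floor lies within the scatter) is nothing beyond the scatter, so no clear direction is expected. For compound 3 the expected value is 9000 nM, with an estimated range of 3500 nM to 20000 nM.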

Compound 3, half-maximal inhibitory concentration: 7000 nM
Beside the measured number, compound 3's estimate is 1.3-fold (0.11 log units) above it; measured number inside the range.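

In this assay compound 1 gives > 10000 nM, which is a limit of the assay and not a number. Placing 3-methoxyphenyl in place of furan-2-yl on a saturated chain carbon bound to an amide-type nitrogen gives an at least 1.4-fold lower number from compound 1 to compound 3 (0.15 log units; that floor lies within the scatter), so this position now has a measured number for a change confined to that one group. The step is only a floor, and its true size stays unknown because one end of it is a limit: the limit of > 10000 nM in this assay, at which 1 of the 3 values shown sits.

The compounds shown leave open whether the methoxy group or the six-membered aromatic ring accounts for the step, as a plain phenyl in the same place would separate the two. Also open, on these data alone, is how a pyridine ring, an amine or a longer chain at this place would read in this assay.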